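The compounds below may be only part of what the source reports. "The series", "measured", "known", "first", "only" and "open" are said of these compounds alone.

Values in a functional assay on A-375 cells (Homo sapiens) for antiproliferative activity; on this read-out lower numbers stand for stronger inhibition and higher numbers for weaker inhibition:
- compound 1 `O=C(Nc1ccc(-c2cccnc2)cc1)C1CCCN(Cc2ccc(F)c(F)c2)C1`: 610 nM
- compound 2 `O=C(Nc1ccc(-c2c[nH]cn2)cc1)C1CCCN(Cc2ccc(F)c(F)c2)C1`: > 20000 nM (a limit of the assay, not a number)
- compound 3 `O=C(Nc1ccc(-c2ncc[nH]2)cc1)C1CCCN(Cc2ccc(F)c(F)c2)C1`: 19000 nM

Of the two exact numbers, compound 3 has the higher, with a 31-fold higher number from compound 1 to compound 3 (1.49 log units; beyond the scatter). Next in the series is compound 4 `O=C(Nc1ccc(-c2cccs2)cc1)C1CCCN(Cc2ccc(F)c(F)c2)C1`, with thiophen-2-yl in place of 1H-imidazol-2-yl on an aromatic carbon, para to a large group: thiophen-2-yl in place of 1H-imidazol-2-yl on an aromatic carbon.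

Going by the values given here, no measured step involves thiophen-2-yl, so the evidence is indirect. Two large steps bear on it, an at least 32-fold higher number from compound 1 to compound 2 (1.51 log units; beyond the scatter) and a 31-fold higher number from compound 1 to compound 3 (1.49 log units; beyond the scatter), and each puts an imidazolyl group where compound 1 has pyridin-3-yl. The two imidazolyl isomers do not separate, with an at least 1.0-fold lower number from compound 2 to compound 3 (0.02 log units; that floor lies within the scatter). On these data alone, compound 4 removes the imidazolyl group, so much of the loss seen from compound 1 is expected to return, though not all of it, as thiophen-2-yl is untested.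

The expected change in this assay is a large one towards a lower number, a 9.5-fold lower number from compound 3 to compound 4 (0.98 log units; beyond the scatter). For compound 4 the estimate is 2000 nM, with an expected range of 400 nM to 9000 nM.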

Compound 4, half-maximal inhibitory concentration: 390 nM
The estimate for compound 4 lay 5.1-fold (0.71 log units) above the measured number; the measured number lies below the stated range.
By their numbers in this assay, from the lowest: compounds 4 and 1 (each within the scatter of the next); then compound 3. At a limit, above all of these: compound 2.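

In this assay, a five-membered aromatic ring on this aromatic carbon, para to a large group, is compatible with activity: a 49-fold lower number from compound 3 to compound 4 (1.69 log units; beyond the scatter), so the loss with 1H-imidazol-2-yl does not come with ring size alone. Thiophen-2-yl and pyridin-3-yl cannot be told apart here, with a 1.6-fold lower number from compound 1 to compound 4 (0.19 log units; within the scatter). The comparison with 1H-imidazol-4-yl gives only a floor, an at least 51-fold lower number from compound 2 to compound 4 (1.70 log units; beyond the scatter), and it rests on a limit of the assay: the limit of > 20000 nM in this assay, at which 1 of the 4 values shown sits.

Thiophen-2-yl differs from 1H-imidazol-2-yl in both its hetero atoms and its hydrogen-bond donor count, and these compounds do not separate the two changes. A 1-methyl-1H-imidazol-2-yl or furan-2-yl group at this position would bear on that question, and neither is among the compounds shown.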